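A few compounds are considered here, and "the series" means these few. Any claim that something is new, unique, unknown or untested is made for them only; others in the source may bear on it.

Measured so far:
Compound 1 `Nc1ccc(-c2nc3ccc(F)cc3s2)cc1I`: 70 nM
Compound 2 `Cc1cc(-c2nc3c(F)cccc3s2)ccc1N`: 5500 nM
Compound 3 `Nc1ccc(-c2nc3cc(F)ccc3s2)cc1`: < 10 nM

In a functional assay on NCI-H226 cells (Homo sapiens) for inhibition (on this read-out higher numbers stand for weaker inhibition of growth and lower numbers for stronger inhibition of growth), compound 1 gives 70 nM, the lower of the two true numbers available. Compound 2 gives 5500 nM, a much higher number and well beyond the scatter. Compound 3 is reported as < 10 nM, which is a limit of the assay and not a number.

Compound 4 `Nc1ccc(-c2nc3ccc(F)cc3s2)cc1Cl` has not been measured. It differs from compound 1 in a single place: chloro in place of iodo on an aromatic carbon. The chloro group replaces the iodo group on an aromatic carbon, ortho to an amino group and meta to a large group.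

Among the compounds with values here, no measured pair shows this swap alone, so in this assay no step beyond the scatter is expected, and neither direction is favoured. The expected step is a 1.2-fold lower number from compound 1 to compound 4 (0.07 log units; within the scatter). Compound 2 at 5500 nM shows how high a close relative can lie, so the range is kept wide. For compound 4 the estimated value is 60 nM, with an expected range from 10 nM to 400 nM.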

Compound 4, concentration for 50% growth inhibition: 14100 nM
Estimate against measurement, compound 4: 240-fold (2.37 log units) below; the measured number lies above the stated range.
By their numbers in this assay, from the lowest: compound 1; then compound 2; then compound 4. At a limit, below all of these: compound 3.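

In this assay, putting chloro in place of iodo gives a 200-fold higher number from compound 1 to compound 4 (2.30 log units; beyond the scatter). The earlier compounds shown here held no pair that tested this place alone, and this one shows that the aromatic carbon ortho to the amino group is highly sensitive: one halogen atom exchanged for another, with the count of heavy atoms, hydrogen-bond donors and hydrogen-bond acceptors unchanged, separates strong from weak inhibition of growth. Nothing among the data shown accounts for so large a step.

Only iodo and chloro can be compared directly at this place on the shared core. Where bromo, which lies between them among the halogens, or a methoxy group would fall remains open, as does whether the number rises gradually or abruptly across such groups.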